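Indazole in Place of Indole on the Anilino Nitrogen

The source may hold more compounds than are shown below. What is called first, only, known or untested is meant among the compounds shown, and "the series" means these compounds.

Compound 3 `Cn1c(=O)c(S(=O)(=O)c2ccc(F)cc2)cc2cnc(Nc3cccc4[nH]ccc34)nc21` gives 750 nM in a functional assay on DU-145 cells (Homo sapiens) for inhibition, read by trypan blue exclusion, with a stated time of 72 h; a lower number here means a stronger inhibitor, a higher number a weaker inhibitor. Compound 2 `Cn1c(=O)c(S(=O)(=O)c2ccc(F)cc2F)cc2cnc(Nc3cccc4[nH]ccc34)nc21` gives 750 nM, and no change at the digits printed from compound 2 to compound 3 (within the scatter); the two stand level, together the lowest of three numbers. Compound 1 `Cn1c(=O)c(S(=O)(=O)c2ccc(F)cc2F)cc2cnc(Nc3ccc4cc[nH]c4c3)nc21` gives 5000 nM, and a 6.7-fold lower number from compound 1 to compound 2 (0.82 log units; beyond the scatter). Compound 4 `Cn1c(=O)c(S(=O)(=O)c2ccc(F)cc2)cc2cnc(Nc3ccc4[nH]ncc4c3)nc21` differs from compound 3 in one place: 1H-indazol-5-yl in place of 1H-indol-4-yl on a nitrogen on an aromatic ring. Among the compounds with values here, no measured step exchanges this pair of rings. Within the data shown here, the only step that touches the ring on this nitrogen is a 6.7-fold lower number from compound 1 to compound 2 (0.82 log units; beyond the scatter), which shows that altering that ring can move the number well beyond the scatter, whereas no change at the digits printed from compound 2 to compound 3 (within the scatter) concerns another part of the molecule. A modest loss is therefore expected, a 2.0-fold higher number from compound 3 to compound 4 (0.30 log units; within the scatter), with wide uncertainty. Compound 4 is estimated at 1500 nM, between 400 nM and 6000 nM.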

Compound 4, half-maximal inhibitory concentration: 5000 nM
Compound 4: the middle estimate sits 3.3-fold (0.52 log units) below what was measured; the measured number falls inside the stated range.
By their numbers in this assay, from the lowest: compounds 2 and 3 (each within the scatter of the next); then compounds 1 and 4 (each within the scatter of the next).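

In this assay, a 6.7-fold higher number from compound 3 to compound 4 (0.82 log units; beyond the scatter), so a second change to the ring on this nitrogen also moves the number beyond the scatter, this time upward and on the compound without the second fluoro. In both one-place changes of this ring, a 6.7-fold lower number from compound 1 to compound 2 (0.82 log units; beyond the scatter) included, the 1H-indol-4-yl compound carries the lower number, and no compound shown goes against this. No supporting evidence explains this result. The step changes both the ring atoms and the attachment position, and these compounds do not separate the two. A 1H-indazol-4-yl or 1H-indol-5-yl group on the same nitrogen would tell them apart.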